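Opening the Bicyclic Amine into a Flexible Chain

This account rests on a few compounds, and the source may have more. Where it says the series, first, only, none or still open, it means among the compounds named here.

Going by the values given here, compound 1 `COc1cc(C)c(S(=O)(=O)N(C)CCOCC(=O)N2CCN([C@@H]3CN4CCC3CC4)CC2)c(C)c1` was tested in an ADME assay on Caco-2 cells (Homo sapiens) for permeability, tested at 50 uM (on this read-out lower numbers stand for lower permeability and higher numbers for higher permeability), and gives 1.4 10^-6 cm/s, the lowest of the two numbers known so far. Its nearest measured neighbour is compound 2 `COc1cc(C)c(S(=O)(=O)N(C)CCOCC(=O)N2CCN(C3CCN(C4CC4)CC3)CC2)c(C)c1`, which in this assay gives 11.8 10^-6 cm/s; the step between the two is an 8.4-fold higher number from compound 1 to compound 2 (0.93 log units; beyond the scatter). Compound 3 `COc1cc(C)c(S(=O)(=O)N(C)CCOCC(=O)N2CCN(CCCN(C)C)CC2)c(C)c1` is not yet measured and differs from compound 1 in one place: a group of 6 heavy atoms (5 carbon, 1 nitrogen; no ring) in place of a group of 8 heavy atoms (7 carbon, 1 nitrogen; 2 six-membered non-aromatic rings with 1 hetero atom each), on an amine nitrogen in a ring. The measured step from compound 1 to compound 2 bears on this question only in part, since there too the group on the ring nitrogen was exchanged, but for a different group. That step was beyond the scatter and pointed upward. On that basis, a rise in this assay is expected for compound 3, though with wide uncertainty, as the entering chain is not the group that was tested. The step expected is a 3.6-fold higher number from compound 1 to compound 3 (0.55 log units; beyond the scatter). For compound 3 the estimate in this assay is 5 10^-6 cm/s, with a range from 1.5 10^-6 cm/s to 15 10^-6 cm/s.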

Compound 3, apparent permeability: 0.1 10^-6 cm/s
The estimate for compound 3 lay 50-fold (1.70 log units) above the measured number; the measured number lies below the stated range.
By their numbers in this assay, from the lowest: compound 3; then compound 1; then compound 2.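

Replacing either ring-containing group with the open 3-(dimethylamino)propyl chain takes the number in this assay down, not up (a 14-fold lower number from compound 1 to compound 3 (1.15 log units; beyond the scatter); a 120-fold lower number from compound 2 to compound 3 (2.07 log units; beyond the scatter)), and both steps are large and beyond the scatter. Going by these compounds alone, the earlier pair showed only that one ring-containing group could give a higher number than another; these new steps show that, among the three compounds, the group on this amine nitrogen in a ring can move the read-out in either direction, and that the open chain sits lowest, under both ring-containing groups. Nothing measured here explains why the chain gives this result.

The three compounds cannot separate the loss of the rings from the particular chain that replaced them, since only one open chain appears among them. A longer chain ending in the same dimethylamino group, or a similar chain ending in a morpholine ring, would be needed to show whether any open chain at this position gives so low a number or only this one does.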